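Methylamino in Place of Hydroxy on the Shared Core

The compounds below may be only part of what the source reports. "The series", "measured", "known", "first", "only" and "open" are said of these compounds alone.

Of the compounds shown here, three built on one shared core have been measured in a functional assay on MT4 cells (Homo sapiens) for cytotoxicity; a lower number here means that less compound is tolerated, a higher number that more compound is tolerated. Compound 1 `Cn1cnc2c(ncn2[C@@H]2O[C@H](CO[Si](C)(C)C(C)(C)C)[C@@]3(OS(=O)(=O)C=C3N)[C@H]2O[Si](C)(C)C(C)(C)C)c1=O` reaches only the limit of the assay, > 150000 nM, so for it no number is known. Compound 2 `COc1ncnc2c1ncn2[C@@H]1O[C@H](CO[Si](C)(C)C(C)(C)C)[C@@]2(OS(=O)(=O)C=C2N)[C@H]1O[Si](C)(C)C(C)(C)C` gives 21000 nM in this assay, and compound 3 `CC(C)(C)[Si](C)(C)OC[C@H]1O[C@@H](n2cnc3c(O)ncnc32)[C@H](O[Si](C)(C)C(C)(C)C)[C@]12OS(=O)(=O)C=C2N` gives 14000 nM. These two numbers lie close together: the step of a 1.5-fold lower number from compound 2 to compound 3 (0.18 log units; within the scatter), in which hydrogen replaces methyl on an oxygen of the aromatic ring, stays within the scatter. Compound 1 stands apart only as a limit (the limit of > 150000 nM in this assay, at which 1 of the 3 values shown sits). Compound 3 therefore gives one of the two actual numbers in this assay. Exchanging the whole aromatic group on the core moved the numbers far more: an at least 7.1-fold lower number from compound 1 to compound 2 (0.85 log units; beyond the scatter) and an at least 10-fold lower number from compound 1 to compound 3 (1.02 log units; beyond the scatter).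

Compound 4 `CNc1ncnc2c1ncn2[C@@H]1O[C@H](CO[Si](C)(C)C(C)(C)C)[C@@]2(OS(=O)(=O)C=C2N)[C@H]1O[Si](C)(C)C(C)(C)C` differs from compound 3 in one place: methylamino in place of hydroxy on an aromatic carbon. This is a small change at the same spot that was already varied in a 1.5-fold lower number from compound 2 to compound 3 (0.18 log units; within the scatter), a step that stayed within the scatter, while the large steps seen so far came from replacing the whole aromatic group. The expected step of a 1.3-fold higher number from compound 3 to compound 4 (0.11 log units; within the scatter) is therefore estimated to remain within the scatter. Compound 4 is expected to give about 18000 nM in this assay, in a range from 6000 nM to 60000 nM.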

Compound 4, half-maximal cytotoxic concentration: 14000 nM
Compound 4: middle estimate off by 1.3-fold (0.11 log units), on the high side, and the stated range covers the measured number.
By their numbers in this assay, from the lowest: compounds 3, 4 and 2 (each within the scatter of the next). At a limit, above all of these: compound 1.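

In this assay, a third group at this aromatic carbon of the six-membered aromatic ring leaves the picture as it was: no change at the digits printed from compound 3 to compound 4 (within the scatter) and a 1.5-fold lower number from compound 2 to compound 4 (0.18 log units; within the scatter), so hydroxy, methoxy and methylamino cannot be told apart here. The earlier compounds shown here showed this only for hydrogen and methyl exchanged on an oxygen, whereas here the atom attached to the ring itself changes from oxygen to nitrogen, and the reading still stays within the scatter. The remaining step, an at least 10-fold lower number from compound 1 to compound 4 (1.02 log units; beyond the scatter), rests on compound 1, which is a limit and not a number: the limit of > 150000 nM in this assay, at which 1 of the 4 values shown sits.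

Going by these compounds, the three groups compared here are all small, so it remains open whether the numbers in this assay would also hold together with a plain amine, a dimethylamino group, a longer chain such as butylamino, or a chlorine atom at this carbon. On these data alone, it also remains open which part of the aromatic group of compound 1 sets it apart, since that group differs from the others in more than one place and its value is only a limit.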